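Replacing a Propyl Ketone with an Isopropyl Amide

The source may hold more compounds than are shown below. What is called first, only, known or untested is meant among the compounds shown, and "the series" means these compounds.

Measured compounds:
compound 1 `CCCOC(=O)C1=C(C)NC(=O)NC1c1cccs1`: 32%
compound 2 `CCCC(=O)C1=C(C)NC(=O)NC1c1ccco1`: 1%
compound 3 `CCCC(=O)C1=C(C)NC(=O)NC1c1cccs1`: 2%

In an assay on membranes from HeLa cells for displacement of a labelled ligand from adenosine receptor A3 (Homo sapiens), read by scintillation counting, with a stated time of 180 min, tested at 1 uM (on this read-out higher numbers stand for more inhibition at the one concentration tested (going by the name of the read-out) and lower numbers for less inhibition), compound 3 stands second highest of the three numbers. Compound 2 lies nearest, with the step of a number 1 percentage points higher from compound 2 to compound 3 (within the scatter) within the scatter, so no order can be read between those two. Compound 1 lies furthest, and the step of a number 30 percentage points lower from compound 1 to compound 3 (beyond the scatter) shows that the group on the carbonyl carbon can shift the read-out considerably.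

Compound 4 `CC1=C(C(=O)NC(C)C)C(c2cccs2)NC(=O)N1` differs from compound 3 in one place: isopropylamino in place of propyl on a carbonyl carbon. Among the compounds with values here, the only measured step that bears on this is a number 30 percentage points lower from compound 1 to compound 3 (beyond the scatter), which concerns the same carbonyl carbon but a different exchange. Because a number 30 percentage points lower from compound 1 to compound 3 (beyond the scatter) was sizeable, a change of similar size in either direction is possible, and compound 4 is estimated at 15%, between 0% and 40%, meaning an expected step of a number 13 percentage points higher from compound 3 to compound 4 (beyond the scatter).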

Compound 4, a percentage reported as inhibition, at one concentration (the size of the read-out at that concentration, not a potency): 1%
Compound 4: middle estimate off by 14 percentage points, on the high side, within the range that was stated.
By their numbers in this assay, from the lowest: compounds 2, 4 and 3 (each within the scatter of the next); then compound 1.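

In this assay, placing isopropylamino on the carbonyl carbon in place of propyl gives a number 1 percentage points lower from compound 3 to compound 4 (within the scatter), so the ketone and this amide cannot be told apart here. Within the data shown here, the second exchange gives a number 31 percentage points lower from compound 1 to compound 4 (beyond the scatter), which leaves propoxy as the only one of the three groups at this position that stands clear of the others. Nothing available explains this difference.

Going by these compounds, it remains open whether an ethoxy or isopropoxy group, or a longer alkoxy chain, would match or exceed compound 1. An unbranched propylamino group on the same carbonyl carbon is also an open case.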